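The source may hold more compounds than are shown below. What is called first, only, known or untested is meant among the compounds shown, and "the series" means these compounds.

Measured compounds in a physicochemical assay for solubility, in phosphate buffer, measured as kinetic solubility; on this read-out higher numbers stand for higher solubility and lower numbers for lower solubility:
compound 1 `CC(C)C(Nc1nccs1)c1ccc(-c2ccc3cccc(F)c3c2)[nH]c1=O`: 16100 nM
compound 2 `CC(C)C(Cc1ncc[nH]1)c1ccc(-c2ccc3cccc(F)c3c2)[nH]c1=O`: 22100 nM
compound 3 `CC(C)[C@H](C[C@H]1CCNC1=O)c1ccc(-c2ccc3cccc(F)c3c2)[nH]c1=O`: 26800 nM

Compound 2 stands second highest of the three numbers, yet its gaps to compound 3 and to compound 1 are both within the scatter, so the three measured compounds are not separated on this read-out.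

The next compound, compound 4 `CC(C)C(Nc1nnc[nH]1)c1ccc(-c2ccc3cccc(F)c3c2)[nH]c1=O`, differs from compound 2 in one place: (4H-1,2,4-triazol-3-yl)amino in place of (1H-imidazol-2-yl)methyl on a saturated chain carbon bound to an aromatic carbon and a saturated chain carbon. Among the compounds with values here, the only measured step that touches this position is a 1.4-fold higher number from compound 1 to compound 2 (0.14 log units; within the scatter), where a thiazolylamino group was swapped for an imidazolylmethyl group on the same chain carbon. That exchange of one five-membered heteroaryl group for another at this site produced nothing beyond the scatter. Within the data shown here, no measured compound carries a triazole or a triazolylamino group, so the present exchange has no direct precedent. Among the measured compounds shown here, on the single relevant step, the expectation for compound 4 is a step of a 1.0-fold lower number from compound 2 to compound 4 (0.00 log units; within the scatter), that is, no change beyond the scatter. Compound 4 is therefore estimated at 22000 nM, with a range from 11000 nM to 44000 nM.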

Compound 4, solubility: 17200 nM
Compound 4: the middle estimate sits 1.3-fold (0.11 log units) above what was measured; the range from low to high includes it.
By their numbers in this assay, from the lowest: compounds 1, 4, 2 and 3 (each within the scatter of the next).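

Two steps now bear on this chain carbon in this assay. Within the data shown here, the step of a 1.1-fold higher number from compound 1 to compound 4 (0.03 log units; within the scatter) is the first to change only the heteroaryl ring while the amine nitrogen stays in place, and it lies within the scatter, so 4H-1,2,4-triazol-3-yl and 1,3-thiazol-2-yl are not separated on that nitrogen. The step of a 1.3-fold lower number from compound 2 to compound 4 (0.11 log units; within the scatter) also lies within the scatter, even though (4H-1,2,4-triazol-3-yl)amino differs from (1H-imidazol-2-yl)methyl in its ring, its link to the chain carbon and its counted hydrogen-bond donors and acceptors.

Still open, on these data alone, is whether a primary amine or a carboxylic acid on this chain carbon would move the read-out beyond the scatter. The available data offer no measurement that explains these small steps.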